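The compounds below may be only part of what the source reports. "The series", "measured", "known", "first", "only" and "open" are said of these compounds alone.

Compound 2 `COc1cc(-c2nn(-c3cccc(NC(=O)c4cccc(C(F)(F)F)c4)c3)cc2-c2ccncc2)ccc1Cl` gives the highest of the three numbers in a functional assay on SK-MEL-5 cells (Homo sapiens) for inhibition, read by sulforhodamine B assay, with a stated time of 48 h (on this read-out lower numbers stand for higher toxicity in this test and higher numbers for lower toxicity in this test), at 40600 nM. Compound 1 `COc1cc(-c2nn(-c3cccc(NC(=O)Nc4cc(C(F)(F)F)cc(C(F)(F)F)c4)c3)cc2-c2ccncc2)ccc1Cl` sits far lower in this assay at 2670 nM, and compound 3 `O=C(Nc1cccc(-n2cc(-c3ccncc3)c(-c3ccc(Cl)c(O)c3)n2)c1)Nc1ccc(Cl)c(Cl)c1` lower still at 2350 nM; both gaps to compound 2 lie well beyond the scatter. Compound 4 `COc1cc(-c2nn(-c3cccc(NC(=O)Nc4cccc(C(F)(F)F)c4)c3)cc2-c2ccncc2)ccc1Cl` is not yet measured. It differs from compound 2 in one place: (3-(trifluoromethyl)phenyl)amino in place of 3-(trifluoromethyl)phenyl on a carbonyl carbon. Compound 1 shares this (3-(trifluoromethyl)phenyl)amino arrangement on the carbonyl carbon, so a large downward step, beyond the scatter, is expected from compound 2 to compound 4, namely an 8.1-fold lower number from compound 2 to compound 4 (0.91 log units; beyond the scatter). For compound 4 in this assay the expected value is 5000 nM, with a likely range from 2000 nM to 15000 nM.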

Compound 4, concentration lethal to 50% of the cells: 2680 nM
Compound 4: middle estimate off by 1.9-fold (0.27 log units), on the high side; the measured number falls inside the stated range.
By their numbers in this assay, from the lowest: compounds 3, 1 and 4 (each within the scatter of the next); then compound 2.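

In this assay the change on the carbonyl carbon alone gives a 15-fold lower number from compound 2 to compound 4 (1.18 log units; beyond the scatter) and so carries the large step by itself. Hydrogen in place of trifluoromethyl on an aromatic carbon gives a 1.0-fold higher number from compound 1 to compound 4 (0.00 log units; within the scatter) and so leaves the number unchanged within the scatter, which means that the low number of compound 1 does not depend on its additional trifluoromethyl. Going by these compounds, whether a methylamino or a benzylamino group on the same carbonyl carbon would give a similarly low number stays open, as does the effect of a chlorine or a methoxy in place of the remaining trifluoromethyl. Nothing given here explains the large step.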